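A few compounds are considered here, and "the series" means these few. Any claim that something is new, unique, unknown or untested is made for them only; others in the source may bear on it.

Measured so far in a physicochemical assay for solubility, read by HPLC, with a stated time of 24 h; a higher number here means a more soluble compound, a lower number a less soluble compound:
compound 1, `CN1CCN(C[C@H]2CN(c3ccc(-n4cc(-c5ccccn5)cn4)c(F)c3)C(=O)O2)CC1`, gives 1690000 nM
compound 2, `O=C1CNC(=O)N1C[C@H]1CN(c2ccc(-n3cc(-c4ccccn4)cn3)c(F)c2)C(=O)O1`, gives 1630000 nM
compound 3, `COC[C@H]1CN(c2ccc(-n3cc(-c4ccccn4)cn3)c(F)c2)C(=O)O1`, gives 36200 nM

Compound 3 stands lowest of the three, beyond the scatter from both others. The move to compound 4, `CCNC(=O)NC[C@H]1CN(c2ccc(-n3cc(-c4ccccn4)cn3)c(F)c2)C(=O)O1`, is (ethylcarbamoyl)amino in place of methoxy on a saturated chain carbon bound to a saturated ring carbon. Going by the values given here, the steps that bear on it are the two reaching compound 3: a 47-fold lower number from compound 1 to compound 3 (1.67 log units; beyond the scatter) and a 45-fold lower number from compound 2 to compound 3 (1.65 log units; beyond the scatter), both large. Each swaps methoxy for a group richer in heavy atoms and polar atoms, as the change to compound 4 does, though neither is the same group. An upward step beyond the scatter is therefore expected, and its size is estimated at an 8.3-fold higher number from compound 3 to compound 4 (0.92 log units; beyond the scatter). Compound 4 is expected to reach about 300000 nM in this assay, within 60000 nM to 1500000 nM.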

Compound 4, solubility: 222000 nM
Beside the measured number, compound 4's estimate is 1.4-fold (0.13 log units) above it, within the range that was stated.
By their numbers in this assay, from the lowest: compound 3; then compound 4; then compounds 2 and 1 (each within the scatter of the next).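

In this assay, (ethylcarbamoyl)amino on a saturated chain carbon bound to a saturated ring carbon gives a 6.1-fold higher number from compound 3 to compound 4 (0.79 log units; beyond the scatter), so a group with no ring can also lift the number over methoxy. It still falls short of the two groups carrying rings, with a 7.3-fold lower number from compound 2 to compound 4 (0.87 log units; beyond the scatter) and a 7.6-fold lower number from compound 1 to compound 4 (0.88 log units; beyond the scatter), so this place now shows an intermediate level rather than only two extremes. Nothing available explains this order.

From the compounds shown here alone, whether a primary amine, a carboxylic acid, or a longer chain in place of the ethyl would land nearer compound 3 or compound 1 stays open.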